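A few compounds are considered here, and "the series" means these few. Any claim that something is new, unique, unknown or untested is made for them only; others in the source may bear on it.

Going by the values given here, compound 2, with the structure `O=C(C1CCOCC1)N1N=CCC1c1ccccc1`, stands at the top of the three numbers so far. In a physicochemical assay for lipophilicity, read by HPLC, measured as chromatographic lipophilicity, at pH 7.4 (a lower number here means a more polar compound, a higher number a more lipophilic compound), compound 2 gives 3.1. Compound 3, `O=C(c1cccnc1)N1CCC(C(=O)N2N=CCC2c2ccccc2)CC1`, in this assay gives 2.6, which lies beyond the scatter below compound 2. Compound 1, `CC(C)(C)C(=O)N1CCNCC1c1ccccc1`, in this assay gives 2.5, the lowest of the three and again beyond the scatter from compound 2. Compound 4, `O=C(c1cccnc1)N1N=CCC1c1ccccc1`, has not yet been measured in this assay. It differs from compound 2 in one place: pyridin-3-yl in place of oxan-4-yl on a carbonyl carbon. Among the compounds with values here, no measured pair shows this same exchange, so the size of the step rests on expectation alone. Compound 3 carries the same pyridin-3-yl group on a carbonyl carbon and sits below compound 2, but the rest of its structure is larger, so it gives no direct guide. The step from compound 2 to compound 4 is expected to be small, a number 0.10 log units lower from compound 2 to compound 4 (within the scatter), downward if anything, and within the scatter. For compound 4 the expected value in this assay is 3, with a range from 2.5 to 3.5.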

Compound 4, distribution coefficient: 2.7
The estimate for compound 4 lay 0.30 log units above the measured number; measured number inside the range.
By their numbers in this assay, from the lowest: compounds 1, 3 and 4 (each within the scatter of the next); then compound 2.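

At the carbonyl carbon whose other neighbour is the amide-type nitrogen in a ring, pyridin-3-yl in place of oxan-4-yl gives a number 0.40 log units lower from compound 2 to compound 4 (beyond the scatter) in this assay. Going by these compounds alone, this is the first measured exchange at this place, and it shows that the reading responds to the identity of the ring even though the two groups match in their counts of heavy atoms, donors and acceptors; they differ in aromaticity and in having nitrogen rather than oxygen as the hetero atom. Nothing measured on these compounds accounts for the size or direction of this step.

The compounds shown do not separate the part played by the aromatic ring from that of the ring nitrogen. From the compounds shown here alone, a phenyl or a piperidin-4-yl group on the same carbonyl carbon would be needed to tell them apart, and whether the step holds on another core also remains open.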